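A few compounds are considered here, and "the series" means these few. Any claim that something is new, unique, unknown or untested is made for them only; others in the source may bear on it.

Of the compounds shown here, three of a shared core have been measured in a functional assay for inhibition, with Homo sapiens as the target; on this read-out higher numbers stand for weaker binding and lower numbers for tighter binding. Compound 1 `O=C(O)CC/C=C\CC1COC(c2cccc3ccccc23)OC1c1cccnc1` gives 631 nM, compound 2 `CC(C)(Oc1ccccc1)C1OCC(C/C=C\CCC(=O)O)C(c2cccnc2)O1` gives 75.9 nM, and compound 3 `CC(C)(Oc1ccc(F)cc1[N+](=O)[O-])C1OCC(C/C=C\CCC(=O)O)C(c2cccnc2)O1` gives 2.51 nM. Compound 2 thus stands second highest of the three numbers: compound 1 is nearest, with an 8.3-fold lower number from compound 1 to compound 2 (0.92 log units; beyond the scatter), and compound 3 is furthest, with a 30-fold lower number from compound 2 to compound 3 (1.48 log units; beyond the scatter).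

Compound 4 `CC(C)(Cc1ccccc1)C1OCC(C/C=C\CCC(=O)O)C(c2cccnc2)O1` differs from compound 2 in one place: benzyl in place of phenoxy on a saturated chain carbon bound to two saturated chain carbons and a saturated ring carbon. Neither measured step tests this kind of change. Among the compounds with values here, the step from compound 1 to compound 2 swaps one whole group for another, and the step from compound 2 to compound 3 adds fluoro and nitro to the phenyl ring while keeping the oxygen; no step removes the oxygen and keeps the ring. Within the data shown here, with no direct precedent, the expected step of a 1.3-fold higher number from compound 2 to compound 4 (0.12 log units; within the scatter) is small, likely within the scatter, and in this assay compound 4 is estimated at 100 nM, within a range from 30 nM to 320 nM.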

Compound 4, dissociation constant: 513 nM
Compound 4: the middle estimate sits 5.1-fold (0.71 log units) below what was measured; measured number above the stated range.
By their numbers in this assay, from the lowest: compound 3; then compound 2; then compounds 4 and 1 (each within the scatter of the next).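

In this assay, keeping the ring and replacing only the oxygen of phenoxy with the carbon of benzyl gives a 6.8-fold higher number from compound 2 to compound 4 (0.83 log units; beyond the scatter), so this position responds to that single atom and not just to the presence of a ring. Set against the fluoro- and nitro-bearing ring, benzyl gives a 200-fold higher number from compound 3 to compound 4 (2.31 log units; beyond the scatter), while swapping in the 1-benzyl-1-methylethyl group for naphthalen-1-yl gives a 1.2-fold lower number from compound 1 to compound 4 (0.09 log units; within the scatter), so those two groups cannot be told apart here. Nothing available explains why this one-atom change matters.

From the compounds shown here alone, whether a sulfur atom or an amine nitrogen in place of the oxygen would keep the lower number remains open. So does whether fluoro and nitro groups on the benzyl ring would bring a gain like the one seen on phenoxy.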